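This account rests on a few compounds, and the source may have more. Where it says the series, first, only, none or still open, it means among the compounds named here.

In a functional assay on MDA-MB-436 cells (Homo sapiens) for antiproliferative activity, read by MTT assay, with a stated time of 24 h (on this read-out higher numbers stand for weaker inhibition and lower numbers for stronger inhibition), three compounds have been measured so far. Compound 1 (`COc1ccccc1C(=O)NC(CC(=O)O)c1ccccc1`) gives > 100000 nM, which is a limit of the assay and not a number. Compound 2 (`CC(C)(C)c1ccc(C(CC(=O)O)NC(=O)c2ccc(F)cc2)cc1`) gives > 100000 nM, again a limit. Compound 3 (`COc1ccccc1C(=O)NC(CC(=O)O)c1ccc(C(C)(C)C)cc1`) gives > 100000 nM, also a limit. The data so far therefore offer only (the limit of > 100000 nM in this assay, at which 3 of the 3 values shown sit).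

Compound 4 (`COc1ccc(C(=O)NC(CC(=O)O)c2ccc(C(C)(C)C)cc2)cc1`) has the same atoms as compound 3, joined differently, with 4-methoxyphenyl in place of 2-methoxyphenyl on a carbonyl carbon.

The measured step that swaps the group on this carbonyl carbon is a step that the two limits leave unreadable from compound 2 to compound 3. The tert-butyl change is a step that the two limits leave unreadable from compound 1 to compound 3. Neither gives a size to carry over, so the expectation in this assay rests on compound 3, whose > 100000 nM is a limit.

No change beyond the scatter is expected in either direction, and the expected step is a step that the limit leaves unreadable from compound 3 to compound 4. For compound 4 the estimated value is 120000 nM, with an expected range from 50000 nM to 300000 nM.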

Compound 4, half-maximal inhibitory concentration: > 100000 nM
Compound 4: a limit, no number (the forecaster's own chance of this, stated with the estimate: 80%); the middle value is on the limit's open side.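

The result for compound 4 is again a limit and not a number, so the steps to it from compound 2 and from compound 3 cannot be read. The compounds shown leave open whether any of them differ in strength, and by how much, since all sit at the same limit: the limit of > 100000 nM in this assay, at which 4 of the 4 values shown sit.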